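The compounds below may be only part of what the source reports. "The series", "measured", "known", "first", "only" and "open" are said of these compounds alone.

Compound 1, `CCCCCCCC(=O)OCCc1c(-c2ccccc2Cl)c2cc(Cl)ccc2[nH]c1=O`, gives 78000 nM in an ADME assay on HepG2 2.2.15 cells (Homo sapiens) for cytotoxicity; on this read-out higher numbers stand for lower toxicity in this test and lower numbers for higher toxicity in this test. Compound 2, `CCOCC(=O)OCCc1c(-c2ccccc2Cl)c2cc(Cl)ccc2[nH]c1=O`, gives 130000 nM in this assay.

Of the two numbers, compound 2's stands at the top, separated from compound 1 by a 1.7-fold higher number from compound 1 to compound 2 (0.22 log units; within the scatter), a gap within the scatter. Compound 3, `O=C(OCCc1c(-c2ccccc2Cl)c2cc(Cl)ccc2[nH]c1=O)c1ccccc1`, differs from compound 2 by phenyl in place of ethoxymethyl on a carbonyl carbon. Among the compounds with values here, the only measured step bearing on this part of the molecule is the one from compound 1 to compound 2, which swapped one chain on a carbonyl carbon for another and moved the number by a 1.7-fold higher number from compound 1 to compound 2 (0.22 log units; within the scatter), within the scatter. Phenyl in place of ethoxymethyl on a carbonyl carbon has no measured precedent here, so the expected step in this assay is none beyond the scatter, in either direction. Compound 3 is therefore estimated at 100000 nM, with a range from 40000 nM to 250000 nM. This expectation corresponds to a 1.3-fold lower number from compound 2 to compound 3 (0.11 log units; within the scatter).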

Compound 3, half-maximal cytotoxic concentration: 43000 nM
For compound 3 the middle estimate is 2.3-fold (0.37 log units) above the measured one; the range from low to high includes it.
By their numbers in this assay, from the lowest: compounds 3, 1 and 2 (each within the scatter of the next, the first and the last beyond it).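

In this assay, within the data shown here, this carbonyl carbon now shows a change beyond the scatter for the first time: phenyl in place of ethoxymethyl gives a 3.0-fold lower number from compound 2 to compound 3 (0.48 log units; beyond the scatter) and counts as modest. Phenyl in place of heptyl gives only a 1.8-fold lower number from compound 1 to compound 3 (0.26 log units; within the scatter) and so stays within the scatter, which means the ring is set apart from one of the two chains and not from both. Nothing measured here explains this difference between the two steps.

From the compounds shown here alone, it remains open whether a cyclohexyl ring in place of phenyl would give a number like that of compound 3, or whether the aromatic ring itself matters. Also open, going by these compounds, is how a phenyl carrying an amine or a carboxylic acid would read on this carbonyl carbon.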